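Adding a Hydroxymethyl to Compound 3

This account rests on a few compounds, and the source may have more. Where it says the series, first, only, none or still open, it means among the compounds named here.

Compound 1, `FC(F)(F)c1ccccc1OC1CCN(c2ccc(-n3ccnc3)nn2)CC1`, gives 4 nM in an assay on microsomes from liver for inhibition of acyl-CoA desaturase 1 (Rattus norvegicus); a lower number here means a stronger inhibitor, a higher number a weaker inhibitor.
Compound 2, `CC(C)(C)c1nnc(-c2ccc(N3CCC(Oc4ccccc4C(F)(F)F)CC3)nn2)o1`, gives 980 nM in this assay.
Compound 3, `FC(F)(F)c1ccccc1OC1CCN(c2ccc(-c3nnco3)nn2)CC1`, gives 22 nM in this assay.

Among these three numbers compound 3 stands second highest: the step of a 5.5-fold higher number from compound 1 to compound 3 (0.74 log units; beyond the scatter) separates it from compound 1, and the step of a 45-fold lower number from compound 2 to compound 3 (1.65 log units; beyond the scatter) from compound 2, both beyond the scatter. Compound 4, `OCc1nnc(-c2ccc(N3CCC(Oc4ccccc4C(F)(F)F)CC3)nn2)o1`, differs from compound 3 by hydroxymethyl in place of hydrogen on an aromatic carbon. Within the data shown here, two measured steps bear on this position. The step of a 45-fold lower number from compound 2 to compound 3 (1.65 log units; beyond the scatter) shows that removing a tert-butyl from this same aromatic carbon lowered the number greatly, and the step of a 250-fold higher number from compound 1 to compound 2 (2.39 log units; beyond the scatter) shows the same group, arriving with the whole ring, raising it greatly. Compound 4 places a different substituent on that carbon, so some rise beyond the scatter is expected, though not necessarily as large. The expected step is a 2.7-fold higher number from compound 3 to compound 4 (0.44 log units; beyond the scatter). Compound 4 is therefore estimated at 60 nM in this assay, with a range from 20 nM to 250 nM.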

Compound 4, half-maximal inhibitory concentration: 2.9 nM
Estimate against measurement, compound 4: 21-fold (1.32 log units) above; measured number outside the range, below it.
By their numbers in this assay, from the lowest: compounds 4 and 1 (each within the scatter of the next); then compound 3; then compound 2.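

On this aromatic carbon, a substituent does not have to raise the number in this assay: hydroxymethyl gives (a 7.6-fold lower number from compound 3 to compound 4 (0.88 log units; beyond the scatter)), so the earlier rise with tert-butyl cannot be read as applying to every group placed there. Among these compounds, the choice of group matters greatly, as exchanging tert-butyl for hydroxymethyl shows (a 340-fold lower number from compound 2 to compound 4 (2.53 log units; beyond the scatter)), and 5-(hydroxymethyl)-1,3,4-oxadiazol-2-yl is the first of the oxadiazole groups to come level with 1H-imidazol-1-yl (a 1.4-fold lower number from compound 1 to compound 4 (0.14 log units; within the scatter)). Nothing measured here accounts for these steps.

Going by these compounds, whether the result belongs to the hydroxyl or to the added carbon stays open. So does how a plain methyl, a methoxymethyl, a longer chain such as hydroxyethyl or an aminomethyl would read on the same carbon.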